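Methylsulfanyl in Place of Methyl: Cytotoxicity Outlook

The source may hold more compounds than are shown below. What is called first, only, known or untested is meant among the compounds shown, and "the series" means these compounds.

Measured so far:
Compound 1, `Cc1ccc(/C=N/N(C(=O)c2ccccc2)C(=O)c2ccncc2)cc1`, in an ADME assay on HEL cells (Homo sapiens) for cytotoxicity (a lower number here means that less compound is tolerated, a higher number that more compound is tolerated), gives > 100 ug/mL.
Compound 2, `O=C(N/N=C/c1c[nH]c2ccccc12)c1ccncc1`, in this assay gives > 100 ug/mL.

For compound 1 the value in this assay is a limit of the assay and not a number. The value of compound 2 in this assay is likewise a limit. Both measured compounds sit at the limit of > 100 ug/mL in this assay, at which 2 of the 2 values shown sit, so compound 1 stands at the limit, and nothing shown separates it from compound 2. Compound 3, `CSc1ccc(/C=N/N(C(=O)c2ccccc2)C(=O)c2ccncc2)cc1`, differs from compound 1 by methylsulfanyl in place of methyl on an aromatic carbon. Going by the values given here, no step between measured compounds is available, so the effect of this change is unmeasured. In this assay the writer expects no step beyond the scatter, with the minimum cytotoxic concentration of compound 3 most likely again reported only as a limit. The estimate for compound 3 is 100 ug/mL, with a range from 50 ug/mL to 200 ug/mL. The expected step is a number no higher from compound 1 to compound 3 (the limit leaves the size open).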

Compound 3, minimum cytotoxic concentration: > 100 ug/mL
Compound 3 ended at the assay's limit (the forecaster's own chance of this, stated with the estimate: 85%); the middle value lies on the limit itself.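

In this assay compound 3 gives > 100 ug/mL, which is a limit of the assay and not a number. Compound 1 also stands at a limit, so no step can be read between compound 1 and compound 3. The compounds shown leave open the concentration at which any of them turns cytotoxic: the limit of > 100 ug/mL in this assay, at which 3 of the 3 values shown sit.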